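From a pyrazinyl to a dimethylphenyl on the pyrazole carbon

The compounds below may be only part of what the source reports. "The series", "measured", "known", "first", "only" and "open" are said of these compounds alone.

The account follows a series sharing one core, described in a functional assay on BJAB cells (Homo sapiens) for antiproliferative activity, with a stated time of 4 days; on this read-out lower numbers stand for an effect already at smaller amounts and higher numbers for an effect only at larger amounts of compound. Compound 1 `Cc1nn(-c2nc(-c3ccc(Cl)c(Cl)c3)c(SC(C)C)s2)c(C(=O)O)c1-c1cnccn1` gives 14000 nM. Among the measured compounds shown here, compound 2 `COc1cc(-c2c(C)nn(-c3nc(-c4ccc(Cl)c(Cl)c4)c(SC(C)C)s3)c2C(=O)O)cc(C(F)(F)F)c1` gives 1380 nM, the lowest of the two numbers so far; its only neighbour is compound 1, and the step of a 10-fold lower number from compound 1 to compound 2 (1.01 log units; beyond the scatter) is large and beyond the scatter. Compound 3 `Cc1cc(C)cc(-c2c(C)nn(-c3nc(-c4ccc(Cl)c(Cl)c4)c(SC(C)C)s3)c2C(=O)O)c1` differs from compound 2 in one place: 3,5-dimethylphenyl in place of 3-methoxy-5-(trifluoromethyl)phenyl on an aromatic carbon. For the measured compounds named here, no measured step bears directly on this change, since the one known step exchanged a heteroaryl for a substituted phenyl, whereas compound 3 keeps a phenyl and only alters its two substituents. Going by the values given here, with no comparable step to lean on, the step from compound 2 to compound 3 is expected to be small, a 1.2-fold higher number from compound 2 to compound 3 (0.06 log units; within the scatter), within or near the scatter. Compound 3 is therefore estimated at 1600 nM, with a range from 600 nM to 4500 nM.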

Compound 3, half-maximal effective concentration: 2700 nM
The estimate for compound 3 lay 1.7-fold (0.23 log units) below the measured number; the measured number falls inside the stated range.
By their numbers in this assay, from the lowest: compounds 2 and 3 (each within the scatter of the next); then compound 1.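

In this assay the exchange of one substituted phenyl for another gives a 2.0-fold higher number from compound 2 to compound 3 (0.29 log units; within the scatter) and so does not separate 3,5-dimethylphenyl from 3-methoxy-5-(trifluoromethyl)phenyl at this position, although the entering group has no oxygen, no fluorine and no hydrogen-bond acceptor. Set against pyrazin-2-yl, 3,5-dimethylphenyl gives a 5.2-fold lower number from compound 1 to compound 3 (0.71 log units; beyond the scatter) and thus a second substituted phenyl also stands apart from the heteroaryl of compound 1, with neither compound 2 nor compound 3 going against this. No measurement at hand explains either result. The compounds shown leave open how an unsubstituted phenyl would compare with these two groups. They also leave open how an amine or a carboxylic acid on the phenyl ring would read at this position.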